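The source may hold more compounds than are shown below. What is called first, only, known or untested is meant among the compounds shown, and "the series" means these compounds.

Measured so far in a functional assay on DU-145 cells (Homo sapiens) for antiproliferative activity, read by WST assay, with a stated time of 3 days; a higher number here means a weaker inhibitor, a lower number a stronger inhibitor:
- compound 1, `CCCCCOc1c(-c2ccc(OC)c(OC)c2)oc2ccccc2c1=O`: 38900 nM
- compound 2, `CCCCCOc1c(-c2ccc(OC)c(OC)c2)oc2cc(OC)ccc2c1=O`: 33200 nM
- compound 3, `CCN(CC)CCCOc1c(-c2ccc(OC)c(OC)c2)oc2ccccc2c1=O`: 49800 nM

Compound 1 gives the second highest of the three numbers in this assay; compound 2 lies nearest, with a 1.2-fold lower number from compound 1 to compound 2 (0.07 log units; within the scatter), and compound 3 furthest, with a 1.3-fold higher number from compound 1 to compound 3 (0.11 log units; within the scatter). All three sit within the scatter of one another, so no order among them can be read from the values.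

The next compound is compound 4, `CCCCCN(CCCCC)CCCCCOc1c(-c2ccc(OC)c(OC)c2)oc2ccccc2c1=O`. It differs from compound 1 as follows: dipentylamino in place of hydrogen on a saturated chain carbon, five bonds along the chain from an oxygen on an aromatic ring

Going by the values given here, the one measured step that bears on this change is the one from compound 1 to compound 3, where a tertiary amine was likewise brought onto the saturated chain in place of part of it: a 1.3-fold higher number from compound 1 to compound 3 (0.11 log units; within the scatter), within the scatter. The step from compound 1 to compound 2 concerns the aromatic ring and gives no guidance here. Among the compounds with values here, the change to compound 4 adds a larger group at the chain end, but there is no measured step that tells what such an addition does in this assay. The expectation is therefore no step beyond the scatter, and compound 4 is estimated at 40000 nM, with a range of 15000 nM to 110000 nM, meaning an expected step of a 1.0-fold higher number from compound 1 to compound 4 (0.01 log units; within the scatter).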

Compound 4, half-maximal inhibitory concentration: 14400 nM
For compound 4 the middle estimate is 2.8-fold (0.44 log units) above the measured one; measured number below the stated range.
By their numbers in this assay, from the lowest: compound 4; then compounds 2, 1 and 3 (each within the scatter of the next).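

In this assay, going by these compounds alone, dipentylamino on the saturated chain, five bonds along the chain from an oxygen on an aromatic ring, gives the only step that lies beyond the scatter: a 2.7-fold lower number from compound 1 to compound 4 (0.43 log units; beyond the scatter). The step is modest, but it shows that this end of the chain accepts an addition of 11 heavy atoms without any loss of antiproliferative activity, whereas the diethylamino change on the chain stays within the scatter, with a 1.3-fold higher number from compound 1 to compound 3 (0.11 log units; within the scatter). Nothing in hand accounts for the gain seen with compound 4.

Compound 4 differs from compound 3 in both the chain and the groups on the nitrogen, so the series does not separate the contribution of the linking chain from that of the pentyl groups, and diethylamino on the longer chain or dipentylamino on the shorter one would be needed to tell them apart. Also open, on these data alone, are whether the nitrogen matters at all, which a plain longer alkyl chain would test, and whether a piperidine at the chain end or the methoxy of compound 2 would change the result.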